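The source may hold more compounds than are shown below. What is called first, only, known or untested is meant among the compounds shown, and "the series" means these compounds.

Compound 1 `COc1ccc(F)cc1CNCCCNc1ccnc2cc(Cc3ccc(F)cc3Cl)ccc12`: 2460 nM
Compound 2 `Fc1ccc(Cc2ccc3c(NCCCNCc4ccco4)ccnc3c2)c(Cl)c1`: 5730 nM
Compound 3 `COc1cccc(CNCCCNc2ccnc3cc(CC(C)C)ccc23)c1O`: 2920 nM

In an ADME assay on HepG2 cells (Homo sapiens) for cytotoxicity, read by luminescence, CellTiter-Glo and ATP content, with a stated time of 72 h (a higher number here means that more compound is needed for the effect, a lower number that less compound is needed), compound 1 gives 2460 nM. For the measured compounds named here, compound 3 gives 2920 nM, which lies within the scatter of compound 1, while compound 2 gives 5730 nM, and the step of a 2.3-fold higher number from compound 1 to compound 2 (0.37 log units; beyond the scatter) is the only single-place change among the measured compounds. Compound 4 `COc1ccc(F)cc1CNCCCNc1ccnc2cc(-c3ccc(C(F)(F)F)cc3)ccc12` has not yet been measured. It differs from compound 1 as follows: 4-(trifluoromethyl)phenyl in place of 2-chloro-4-fluorobenzyl on an aromatic carbon. Going by the values given here, the one measured step concerns a group on a saturated chain carbon bound to an amine nitrogen, not the aromatic carbon changed here, so it bears on compound 4 only in showing that swapping one aromatic group on the chain moved the number modestly. Among the compounds with values here, compound 3 differs from compound 1 in two places and offers no step of its own. Within the data shown here, with no direct precedent, the step of a 1.2-fold higher number from compound 1 to compound 4 (0.09 log units; within the scatter) is expected to stay within the scatter, or at most to be modest in either direction. Compound 4 is therefore estimated at 3000 nM, with a range from 1200 nM to 7500 nM.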

Compound 4, half-maximal effective concentration: 5190 nM
Compound 4: the middle estimate sits 1.7-fold (0.24 log units) below what was measured, and the stated range covers the measured number.
By their numbers in this assay, from the lowest: compounds 1, 3, 4 and 2 (each within the scatter of the next, the first and the last beyond it).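

In this assay, placing 4-(trifluoromethyl)phenyl in place of 2-chloro-4-fluorobenzyl on this aromatic carbon gives a 2.1-fold higher number from compound 1 to compound 4 (0.32 log units; beyond the scatter), the first step read at this position. It shows that a change here, and not only one on the saturated chain carbon, can move the number beyond the scatter, and this step and a 2.3-fold higher number from compound 1 to compound 2 (0.37 log units; beyond the scatter) are both modest. No measurement bears on why the number moved at this position.

The step replaces the benzyl group with a phenyl group and changes the ring substituents at the same time, so the compounds shown cannot say which of these changes accounts for it. Also open, from the compounds shown here alone, is how an unsubstituted phenyl, an amine or a carboxylic acid at this aromatic carbon would read in this assay.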